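The compounds below may be only part of what the source reports. "The series", "measured", "known", "first", "only" and "open" are said of these compounds alone.

Compound 1, `Cc1ccc(OCC(=O)N(Cc2cccs2)CC(C)C)cc1`, is one of two compounds with a number in an assay on HEK293 cells for agonist activity at transient receptor potential cation channel subfamily M member 8 (Homo sapiens), read by fluorescence and calcium flux, with a stated time of 15 min; on this read-out higher numbers stand for an effect only at larger amounts of compound and lower numbers for an effect already at smaller amounts. In this assay compound 1 gives 900 nM, the higher of the two, while compound 2, `CCN(Cc1cccs1)C(=O)c1cc2cc(C)ccc2o1`, gives 120 nM, a difference that lies beyond the scatter. The two share the thiophene-bearing arm on the amide nitrogen but differ in several places at once, so no single step can be read from them.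

Compound 3, `Cc1ccc(OCC(=O)N(O)Cc2cccs2)cc1`, has not yet been measured. It differs from compound 1 in one place: hydroxy in place of isobutyl on an amide-type nitrogen.

Among the measured compounds shown here, with no measured pair showing this change, the expectation rests on the two numbers alone. The step from compound 1 to compound 3 is expected to go toward a higher number, a 4.4-fold higher number from compound 1 to compound 3 (0.65 log units; beyond the scatter), beyond the scatter. Compound 3 is therefore estimated at 4000 nM, within a range of 1000 nM to 20000 nM.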

Compound 3, half-maximal effective concentration: 8000 nM
Compound 3: the middle estimate sits 2.0-fold (0.30 log units) below what was measured, within the range that was stated.
By their numbers in this assay, from the lowest: compound 2; then compound 1; then compound 3.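

In this assay, among the compounds shown here, the change on the amide-type nitrogen gives the first readable step: hydroxy in place of isobutyl gives an 8.9-fold higher number from compound 1 to compound 3 (0.95 log units; beyond the scatter), showing that the number at this position depends on the group the nitrogen carries, at least for this one exchange. The change removes 4 heavy atoms of carbon and brings in 1 oxygen with a hydrogen-bond donor and a hydrogen-bond acceptor, and this single step cannot tell these differences apart. Nothing measured here gives a reason for the step.

Going by these compounds, it remains open whether the higher number follows from the loss of isobutyl or from the arrival of hydroxy. A methyl, a methoxy or a longer chain on the same nitrogen could help separate the two, and compound 2 cannot settle this, as it differs from compound 1 in several places.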